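Halogen swap on the aryl amine of compound 3

This account rests on a few compounds, and the source may have more. Where it says the series, first, only, none or still open, it means among the compounds named here.

The series shares one core, carried by compound 1 `Fc1cccc(-c2nc(Nc3ccccc3)c3cc(F)ccc3n2)c1`, compound 2 `COc1ccccc1Nc1nc(-c2cccc(F)c2)nc2ccc(F)cc12` and compound 3 `Fc1cccc(-c2nc(Nc3ccc(Cl)cc3)c3cc(F)ccc3n2)c1`. In a functional assay on MDA-MB-231 cells (Homo sapiens) for cytotoxicity, read by MTT assay, with a stated time of 48 h (on this read-out higher numbers stand for weaker inhibition and lower numbers for stronger inhibition), compound 1 gives 47800 nM. Compound 2 reaches only the limit of this assay, > 50000 nM, which is a bound and not a number. Compound 3 likewise stands at the limit, > 50000 nM, so its position is known only as a bound. The step of an at least 1.0-fold higher number from compound 1 to compound 2 (0.01 log units; that floor lies within the scatter) and the step of an at least 1.0-fold higher number from compound 1 to compound 3 (0.01 log units; that floor lies within the scatter) are each read against that bound, and a step that the two limits leave unreadable from compound 2 to compound 3 cannot be sized at all, as the limit of > 50000 nM in this assay, at which 2 of the 3 values shown sit, shows.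

Compound 4 `Fc1cccc(-c2nc(Nc3cccc(Br)c3)c3cc(F)ccc3n2)c1` differs from compound 3 by 3-bromophenyl in place of 4-chlorophenyl on a nitrogen on an aromatic ring. Among the compounds with values here, no measured step reads cleanly on this change, since every comparison among the halogenated or substituted aryl amines ends at the limit. The expected step from compound 3 to compound 4 is a number no higher from compound 3 to compound 4 (the limit leaves the size open), with no direction claimed beyond the scatter. For compound 4 the estimate in this assay is 50000 nM, within 25000 nM to 100000 nM, and it is expected most likely to be reported again only as a limit.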

Compound 4, half-maximal inhibitory concentration: > 50000 nM
Compound 4: a limit, no number; the forecaster's own chance of this, stated with the estimate: 65%; the middle value sits exactly at the limit.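

In this assay, 3-bromophenyl on the nitrogen gives a limit and no number, as 4-chlorophenyl and 2-methoxyphenyl did, so this position now shows the same outcome with a bromo group as well. Within the data shown here, the only comparison that can be read is an at least 1.0-fold higher number from compound 1 to compound 4 (0.01 log units; that floor lies within the scatter), and the steps to compound 4 from compound 2 and from compound 3 cannot be read. The position therefore gives no ranking among its substituted aryl amines: the limit of > 50000 nM in this assay, at which 3 of the 4 values shown sit.

From the compounds shown here alone, whether a carboxylic acid or an aminomethyl group on this phenyl ring would give a measurable value remains open. The compounds shown also leave open how any of these aryl amines differ from one another beyond the limit.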